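A few compounds are considered here, and "the series" means these few. Any claim that something is new, unique, unknown or untested is made for them only; others in the source may bear on it.

Measured so far:
compound 1 `CC(C)(C)c1ccc(-c2ccc(-c3ccc(C(=N)N)cc3)o2)cc1` — 3700 nM
compound 2 `N=C(N)c1ccc(-c2ccc(-c3ccc(Br)cc3)o2)cc1` — 2600 nM
compound 3 `N=C(N)c1ccc(-c2ccc(-c3ccc([N+](=O)[O-])cc3)o2)cc1` — 3200 nM

In a functional assay on MCF7 cells (Homo sapiens) for cytotoxicity, read by MTT assay, with a stated time of 96 h (a lower number here means a stronger inhibitor, a higher number a weaker inhibitor), compound 1 has the highest number of the three, but its steps to the others are small: a 1.4-fold lower number from compound 1 to compound 2 (0.15 log units; within the scatter) and a 1.2-fold lower number from compound 1 to compound 3 (0.06 log units; within the scatter), both within the scatter. The pair compound 2 to compound 3 also moves little: a 1.2-fold higher number from compound 2 to compound 3 (0.09 log units; within the scatter). Three changes at the same aromatic carbon have thus left this assay unmoved.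

Compound 4 `CCc1ccc(-c2ccc(-c3ccc(C(=N)N)cc3)o2)cc1` differs from compound 1 in one place: ethyl in place of tert-butyl on an aromatic carbon. The two steps from compound 1 bear on it, since they alter the same group, and neither reached beyond the scatter. No step beyond the scatter is therefore expected in either direction. Compound 4 is estimated at 3500 nM, with a range of 1500 nM to 8000 nM, which would mean a 1.1-fold lower number from compound 1 to compound 4 (0.02 log units; within the scatter).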

Compound 4, half-maximal inhibitory concentration: 3200 nM
Estimate against measurement, compound 4: 1.1-fold (0.04 log units) above; the range from low to high includes it.
By their numbers in this assay, from the lowest: compounds 2, 3, 4 and 1 (each within the scatter of the next).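

Ethyl at this aromatic carbon adds a smaller alkyl group to the comparison, and in this assay the steps read a 1.2-fold lower number from compound 1 to compound 4 (0.06 log units; within the scatter), no change at the digits printed from compound 3 to compound 4 (within the scatter) and a 1.2-fold higher number from compound 2 to compound 4 (0.09 log units; within the scatter). Going from tert-butyl to ethyl takes the group from 4 heavy atoms to 2 heavy atoms, yet tert-butyl, ethyl, bromo and nitro all stay within the scatter of one another. Nothing available explains this flat result.

From the compounds shown here alone, whether an amine, a carboxylic acid or a longer alkyl chain at this carbon would give a step beyond the scatter remains open. So does the effect of changes elsewhere on the shared core.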